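From Dimethylamino to Piperidin-3-yl on the Shared Core

A few compounds are considered here, and "the series" means these few. Any claim that something is new, unique, unknown or untested is made for them only; others in the source may bear on it.

Compound 3 `CN(C)c1cc(-c2cc(N3C[C@H](O)[C@@H](O)C3)ccc2O)nc(N)n1` offers no starting number: in a functional assay on EJ cells (Homo sapiens) for cytotoxicity, with a stated time of 48 h (a higher number here means a weaker inhibitor of growth, a lower number a stronger inhibitor of growth), compound 3 stands as "not determined" (no result reported). Compound 4 `Nc1nc(-c2cc(N3C[C@H](O)[C@@H](O)C3)ccc2O)cc(C2CCCNC2)n1` carries piperidin-3-yl in place of dimethylamino on an aromatic carbon. The closest evidence comes from two compounds with a non-aromatic ring on that carbon: compound 1 `Nc1nc(-c2cc(N3C[C@H](O)[C@@H](O)C3)ccc2O)cc(C2CCCCCC2)n1` gives 700 nM, and compound 2 `Nc1nc(-c2cc(N3C[C@H](O)[C@@H](O)C3)ccc2O)cc(C2CCCCC2)n1` gives 1200 nM. Going by the values given here, the one measured step shows a 1.7-fold higher number from compound 1 to compound 2 (0.23 log units; within the scatter). With no number for compound 3, no size or direction can be expected for the step to compound 4. The expectation therefore rests on these two values, with a wide margin for the ring nitrogen, which neither compound has. The estimate for compound 4 is 1500 nM, with an expected range from 400 nM to 6000 nM.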

Compound 4, concentration for 50% growth inhibition: > 10000 nM
Compound 4: no number, only a limit; the forecaster's own chance of this, stated with the estimate: 10%; middle value at least 6.6-fold (0.82 log units) away from the limit.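

In this assay compound 4 gives > 10000 nM, which is a limit of the assay and not a number. On this aromatic carbon, piperidin-3-yl brings a clear loss against both carbon rings, with an at least 8.3-fold higher number from compound 2 to compound 4 (0.92 log units; beyond the scatter) and an at least 14-fold higher number from compound 1 to compound 4 (1.15 log units; beyond the scatter). The earlier change of ring size, a 1.7-fold higher number from compound 1 to compound 2 (0.23 log units; within the scatter), showed no such loss, so a ring holding nitrogen separates from the all-carbon rings here.

Going by these compounds, how far the true value of compound 4 lies past the limit stays open: the limit of > 10000 nM in this assay, at which 1 of the 4 values shown sits. Whether a piperidin-4-yl group or a tetrahydropyran-3-yl ring would behave in the same way also stays open.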